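Pyrimidin-2-yl for 2-fluorophenyl: a substitution on the ring nitrogen

This account rests on a few compounds, and the source may have more. Where it says the series, first, only, none or still open, it means among the compounds named here.

Of the compounds shown here, two have been measured on a shared core. Compound 1 `CCN1CCN(CC(=O)Nc2nc3ccccc3[nH]2)CC1` and compound 2 `O=C(CN1CCN(c2ccccc2F)CC1)Nc1nc2ccccc2[nH]1` differ only at one ring nitrogen. In a functional assay, read by spectrophotometry, with a stated time of 30 min, tested at 200 ug/mL (a higher number here means a stronger effect of the compound at the concentration tested, a lower number a weaker effect), compound 1 gives 65.8%, and compound 2 gives 70.6%. Among the measured compounds shown here, the single measured step, a number 4.8 percentage points higher from compound 1 to compound 2 (within the scatter), puts 2-fluorophenyl in place of ethyl on an amine nitrogen in a ring and lies within the scatter. Compound 2 thus holds the upper of the two numbers shown, but it cannot be set apart from compound 1.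

Compound 3 `O=C(CN1CCN(c2ncccn2)CC1)Nc1nc2ccccc2[nH]1` now carries a change at the same place: pyrimidin-2-yl in place of 2-fluorophenyl on an amine nitrogen in a ring. For the measured compounds named here, the one step that bears on it, a number 4.8 percentage points higher from compound 1 to compound 2 (within the scatter), altered the group on this ring nitrogen without moving the read-out beyond the scatter, and no measured step exchanges one aromatic ring for another. On that basis the account expects no step beyond the scatter in this assay, that is a number 4.6 percentage points lower from compound 2 to compound 3 (within the scatter). For compound 3 the estimated activity is 66%, with a range from 48% to 80%.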

Compound 3, a percentage reported as activity, at one concentration (the size of the read-out at that concentration, not a potency): 81.8%
Estimate against measurement, compound 3: 15.8 percentage points below, and the stated range ends below it.
By their numbers in this assay, from the lowest: compounds 1 and 2 (each within the scatter of the next); then compound 3.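

In this assay, among the compounds shown here, the exchange of 2-fluorophenyl for pyrimidin-2-yl on the ring nitrogen gives a number 11.2 percentage points higher from compound 2 to compound 3 (beyond the scatter), the first step at this position that lies beyond the scatter. Compounds 2 and 3 both carry a six-membered aromatic ring on this nitrogen, so having such a ring there does not by itself set the read-out; what differs is a ring of carbon only with 0 hydrogen-bond acceptors against a ring with 2 hetero atoms and 2 hydrogen-bond acceptors. Pyrimidin-2-yl in place of ethyl also gives a number 16 percentage points higher from compound 1 to compound 3 (beyond the scatter), whereas 2-fluorophenyl in place of ethyl gave a number 4.8 percentage points higher from compound 1 to compound 2 (within the scatter), and no measurement at hand accounts for the difference between these two aromatic groups.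

The three compounds leave open whether the higher number goes with the ring nitrogens of pyrimidin-2-yl or with the loss of the fluorine, as this one change does both at once; a plain phenyl or a pyridin-2-yl on the same nitrogen would bear on that question. Going by these compounds, each number is also a read-out at one concentration, so how the compounds compare in potency remains open.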